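The source may report more compounds than this note shows. Statements on the series, on what has been measured and on what is new or still open speak of the compounds shown alone.

Measured so far:
compound 1 `Cc1cc2ccccc2nc1-c1cn(-c2ccc(F)cc2)nn1`: > 100 ug/mL
compound 2 `CCCCCc1cc2ccccc2nc1-c1cn(CCC(F)(F)C(F)(F)C(F)(F)C(F)(F)C(F)(F)C(F)(F)C(F)(F)C(F)(F)F)nn1`: > 100 ug/mL

In a functional assay on THP-1 cells (Homo sapiens) for cytotoxicity, read by MTT assay, with a stated time of 24 h (a lower number here means a stronger inhibitor, a higher number a weaker inhibitor), compound 1 gives > 100 ug/mL, which is a limit of the assay rather than a number. Compound 2 likewise gives > 100 ug/mL, again a limit. Both values sit at the limit of > 100 ug/mL in this assay, at which 2 of the 2 values shown sit, so compound 1 stands at the limit with no number of its own. Compound 3 `CCCc1cc2ccccc2nc1-c1cn(-c2ccc(F)cc2)nn1` differs from compound 1 by ethyl in place of hydrogen on a saturated chain carbon bound to an aromatic carbon. No step between measured compounds is shown, and no change beyond the scatter is expected here. Compound 3 is expected to give 100 ug/mL, within 40 ug/mL to 300 ug/mL. The expected step is a number no higher from compound 1 to compound 3 (the limit leaves the size open).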

Compound 3, half-maximal inhibitory concentration: > 100 ug/mL
Compound 3 gave a limit, no number; the forecaster's own chance of this, stated with the estimate: 75%; the middle value lies on the limit itself.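

Compound 1 and compound 3 both stand at a limit rather than a number, so no step can be read between them. The compounds shown leave open whether ethyl in place of hydrogen changes the read-out at all.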